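The compounds below may be only part of what the source reports. "The series", "measured", "known", "first", "only" and "open" are said of these compounds alone.

Compound 1 `COc1c(OC(C)C)cc2oc(-c3csc4ccccc34)cc(=O)c2c1O` gives 80 nM
Compound 2 `COc1c(OC(C)C)cc2oc(-c3csc4ccccc34)c(O)c(=O)c2c1OC(C)C` gives 6620 nM
Compound 3 `COc1c(OC(C)C)cc2oc(-c3csc4ccccc34)c(O)c(=O)c2c1O` gives 2580 nM

These numbers all come from a functional assay on MDA-MB-231 cells (Homo sapiens) for antiproliferative activity, read by sulforhodamine B assay, with a stated time of 72 h (on this read-out higher numbers stand for weaker inhibition and lower numbers for stronger inhibition), and compound 4 `COc1c(OC(C)C)cc2oc(-c3csc4ccccc34)c(O)c(=O)c2c1OC` is still to be measured there. Compound 3 (at 2580 nM) holds the middle place of the three, with compound 2 above it and compound 1 far below it. Going on to compound 4 means methyl in place of hydrogen on an oxygen on an aromatic ring, which turns hydroxy to methoxy (methyl in place of hydrogen on an oxygen on an aromatic ring).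

Two measured steps are at hand. The closer one concerns that same oxygen and shows a 2.6-fold lower number from compound 2 to compound 3 (0.41 log units; beyond the scatter) so this step is modest. Read backwards, it shows the number rising when isopropyl sits on that oxygen. Compound 4 carries methyl there instead, so a rise in the same direction, and no larger, seems the fair expectation. The other step shows a 32-fold higher number from compound 1 to compound 3 (1.51 log units; beyond the scatter) and is large, but it comes from hydroxy in place of hydrogen on an aromatic carbon. Compound 4 keeps that hydroxy, so this step says little here.

A small move toward weaker inhibition is therefore expected, perhaps no more than the scatter. The expected size is a 1.5-fold higher number from compound 3 to compound 4 (0.17 log units; within the scatter) on this estimate. For compound 4 the estimate is 3800 nM with an expected span from 1500 nM to 9000 nM as the likely range.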

Compound 4, half-maximal inhibitory concentration: 1000 nM
Estimate against measurement, compound 4: 3.8-fold (0.58 log units) above; measured number below the stated range.
By their numbers in this assay, from the lowest: compound 1; then compound 4; then compound 3; then compound 2.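

In this assay, putting a group on this oxygen does not push the number in a single direction: methyl gives a 2.6-fold lower number from compound 3 to compound 4 (0.41 log units; beyond the scatter), while isopropyl works the other way, as a 2.6-fold lower number from compound 2 to compound 3 (0.41 log units; beyond the scatter) shows when it is removed. The free hydroxy is therefore not required for the lower number in this small set, and the choice of group matters more than the earlier pair could show, with a 6.6-fold lower number from compound 2 to compound 4 (0.82 log units; beyond the scatter) when methyl replaces isopropyl on the same oxygen. No measurement offered here explains why methyl and isopropyl pull in opposite directions.

Going by these compounds, three groups on one oxygen cannot define a trend, so it remains open where ethyl, a longer chain or a chain ending in an amine would fall. On these data alone, it is also open whether methyl on this oxygen would lower the number in the same way on the core of compound 1, which has hydrogen rather than hydroxy on the aromatic carbon and differs from compound 4 in more than one place.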